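The source may hold more compounds than are shown below. What is called first, only, known or untested is meant among the compounds shown, and "the series" means these compounds.

Three compounds share one core and differ only in the group that sits on a saturated chain carbon bound to a nitrogen on an aromatic ring. In an in vitro assay on CHOK cells for displacement of a labelled ligand from growth hormone secretagogue receptor type 1 (Homo sapiens) (a higher number here means a weaker inhibitor, a lower number a stronger inhibitor), compound 1 `Nc1nc(N)c(-c2ccc(NCc3ccnc(Cl)c3)cc2)c(COCc2ccccc2)n1` gives 1.5 nM, compound 2 `Nc1nc(N)c(-c2ccc(NCc3csc(Cl)c3)cc2)c(COCc2ccccc2)n1` gives 6.3 nM, and compound 3 `Nc1nc(N)c(-c2ccc(NCc3ccncc3)cc2)c(COCc2ccccc2)n1` gives 21 nM, the highest of the three numbers. The change tert-butyl in place of pyridin-4-yl on a saturated chain carbon bound to a nitrogen on an aromatic ring leads to compound 4 `CC(C)(C)CNc1ccc(-c2c(N)nc(N)nc2COCc2ccccc2)cc1`. Among the compounds with values here, no measured step replaces this aromatic ring with a group that has no ring; the nearest comparisons, a 3.3-fold higher number from compound 2 to compound 3 (0.52 log units; beyond the scatter) and a 14-fold higher number from compound 1 to compound 3 (1.15 log units; beyond the scatter), show that changes at this position moved this assay by modest to large amounts. A further rise is therefore expected, though with wide uncertainty, as the estimated step of a 2.1-fold higher number from compound 3 to compound 4 (0.33 log units; beyond the scatter). Compound 4 is expected to give about 45 nM, between 10 nM and 200 nM.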

Compound 4, half-maximal inhibitory concentration: 67 nM
Estimate against measurement, compound 4: 1.5-fold (0.17 log units) below, and the stated range covers the measured number.
By their numbers in this assay, from the lowest: compound 1; then compound 2; then compound 3; then compound 4.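

Within the data shown here, with tert-butyl, the only group here without a ring, this assay shows a 3.2-fold higher number from compound 3 to compound 4 (0.50 log units; beyond the scatter) and, against the two chlorinated aromatic groups, an 11-fold higher number from compound 2 to compound 4 (1.03 log units; beyond the scatter) and a 45-fold higher number from compound 1 to compound 4 (1.65 log units; beyond the scatter) as well. An aromatic ring at this position is therefore not needed for a nanomolar value, yet all three aromatic groups give lower numbers than tert-butyl. Nothing available explains this difference. On these data alone, whether cyclohexyl or piperidin-4-yl, saturated rings of similar size, would track the aromatic groups or tert-butyl remains open.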